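The compounds below may be only part of what the source reports. "The series", "measured", "known", "first", "only" and "open" are said of these compounds alone.

Measured compounds:
Compound 1, `O=C(NCc1cnnn1Cc1ccc2oc(-c3ccc(Cl)cc3)cc(=O)c2c1)c1ccccc1`: 32900 nM
Compound 2, `O=C(CCc1cn(Cc2ccc3oc(-c4ccccc4)cc(=O)c3c2)nn1)Nc1ccc(Cl)cc1`: 15600 nM

In an assay on isolated protein for inhibition of Amine oxidase [flavin-containing] B (Homo sapiens), read by fluorescence and spectrophotometry (a lower number here means a stronger inhibitor, a higher number a weaker inhibitor), compound 2 gives 15600 nM, the lower of the two numbers. In the same assay compound 1 gives 32900 nM, a higher number that lies beyond the usual scatter of repeated measurements. No single-point step between these two compounds has been shown, so only their two values can be compared, and no pattern is claimed from them.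

Compound 3, `O=C(CCCCc1cn(Cc2ccc3oc(-c4ccccc4)cc(=O)c3c2)nn1)Nc1ccc(F)cc1`, has not yet been measured in this assay. It differs from compound 2 in one place: 2-((4-fluorophenyl)carbamoyl)ethyl in place of (4-chlorophenyl)carbamoyl on a saturated chain carbon, two bonds along the chain from an aromatic carbon. No step of this kind has been measured among the compounds shown, so the direction of the change cannot be read from the data. The step of a 1.3-fold higher number from compound 2 to compound 3 (0.11 log units; within the scatter) is expected to be small, within the scatter or leaning slightly toward a weaker inhibitor. For compound 3 the estimate in this assay is 20000 nM, with a range from 7000 nM to 60000 nM.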

Compound 3, half-maximal inhibitory concentration: 15600 nM
Compound 3: middle estimate off by 1.3-fold (0.11 log units), on the high side, and the stated range covers the measured number.
By their numbers in this assay, from the lowest: compounds 2 and 3 (each within the scatter of the next); then compound 1.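

In this assay, putting 2-((4-fluorophenyl)carbamoyl)ethyl in place of (4-chlorophenyl)carbamoyl on a saturated chain carbon, two bonds along the chain from an aromatic carbon, gives no change at the digits printed from compound 2 to compound 3 (within the scatter). This is the first step shown at this position, and it shows that this one exchange, which lengthens the chain and replaces chlorine with fluorine, leaves the number within the scatter, so the inhibitor remains equally weak in this comparison. Nothing available explains this result.

Because chain length and halogen change together in this single step, the contribution of each remains unresolved, and the two may or may not offset one another. Going by these compounds, it also remains open whether an amine or a carboxylic acid at the end of the chain, or a still longer chain, would move the number in this assay.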